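A triazole swap at the limit of measurement

The source may hold more compounds than are shown below. What is called first, only, known or untested is meant among the compounds shown, and "the series" means these compounds.

Compound 1 `Cc1ncc([N+](=O)[O-])n1CC(O)CSC(=S)N(C)C`: > 5000000 nM
Compound 2 `Cc1ncc([N+](=O)[O-])n1CC(O)CN1CCCCC1`: > 5000000 nM
Compound 3 `Cc1ncc([N+](=O)[O-])n1CC(O)Cn1ccnn1`: > 5000000 nM

All three entries come from a toxicity assay on HeLa cells (Homo sapiens) for cytotoxicity, read by MTT assay, with a stated time of 24 h (on this read-out higher numbers stand for weaker inhibition and lower numbers for stronger inhibition), and each is a limit rather than a number. The whole record amounts to the limit of > 5000000 nM in this assay, at which 3 of the 3 values shown sit. Compound 3 stands at that limit, with > 5000000 nM, so no number marks its place.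

Compound 4 `Cc1ncc([N+](=O)[O-])n1CC(O)Cn1cncn1` carries 1H-1,2,4-triazol-1-yl in place of 1H-1,2,3-triazol-1-yl, on a saturated chain carbon, two bonds along the chain from an oxygen on a saturated carbon. The two have the same atoms, joined differently: 1H-1,2,4-triazol-1-yl in place of 1H-1,2,3-triazol-1-yl on a saturated chain carbon, two bonds along the chain from an oxygen on a saturated carbon.

The closest guide is a step that the two limits leave unreadable from compound 2 to compound 3. The other two changes, a step that the two limits leave unreadable from compound 1 to compound 3 and a step that the two limits leave unreadable from compound 1 to compound 2, give no size either. No step beyond the usual scatter is therefore expected in this assay, and no direction can be favoured. The expected step is a step that the limit leaves unreadable from compound 3 to compound 4, and a further limit is the likeliest report. For compound 4 the estimated value is 6000000 nM, with an expected range from 2500000 nM to 15000000 nM.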

Compound 4, half-maximal inhibitory concentration: 4970000 nM
Compound 4: the middle estimate sits 1.2-fold (0.08 log units) above what was measured, within the range that was stated.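

In this assay compound 4 gives 4970000 nM as a true number, the first in this series. Compound 3 gives > 5000000 nM as a limit only. The steps to compound 4 all start from such a limit: the record shows a number no higher from compound 3 to compound 4 (the limit leaves the size open), a number no higher from compound 2 to compound 4 (the limit leaves the size open) and a number no higher from compound 1 to compound 4 (the limit leaves the size open), so their size cannot be read. Placing 1H-1,2,4-triazol-1-yl instead of 1H-1,2,3-triazol-1-yl on this saturated chain carbon therefore adds one measured value at the edge of the readable range, not a sized effect: the limit of > 5000000 nM in this assay, at which 3 of the 4 values shown sit.

The compounds shown leave open whether a morpholine ring, a primary amine or a carboxylic acid on this saturated chain carbon would give a value well clear of that limit. They also leave open whether any change at this place can move the reading far from it.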